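The source may hold more compounds than are shown below. What is called first, only, known or untested is meant among the compounds shown, and "the series" means these compounds.

Compound 1 (`COc1ccc(C(=O)/C=C/c2cc(OC)c(OC)c(OC)c2)c2c1C=CC(C)(C)O2`) gives > 10000 nM as a limit
Compound 2 (`COc1ccc(/C=C/C(=O)c2ccc(OC)c3c2OC(C)(C)C=C3)c(F)c1`) gives > 10000 nM as a limit
Compound 3 (`COc1cc(OC)c(OC)cc1/C=C/C(=O)c1ccc(OC)c2c1OC(C)(C)C=C2`) gives > 10000 nM as a limit

All three entries come from a functional assay on K562 cells (Homo sapiens) for antiproliferative activity, read by MTT assay, with a stated time of 24 h (a higher number here means a weaker inhibitor, a lower number a stronger inhibitor), and are limits of the assay, not numbers. Going by the values given here, the series so far offers only the limit of > 10000 nM in this assay, at which 3 of the 3 values shown sit, and so gives no ranking. Compound 2 stands at > 10000 nM as a limit, with no number to anchor a comparison.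

The next compound is compound 4 (`COc1ccc(C(=O)/C=C/c2ccc(N(C)C)cc2)c2c1C=CC(C)(C)O2`), which differs from compound 2 by 4-(dimethylamino)phenyl in place of 2-fluoro-4-methoxyphenyl on a double-bonded chain carbon bound to a double-bonded chain carbon as the counted change. In words, it has 4-(dimethylamino)phenyl in place of 2-fluoro-4-methoxyphenyl on a double-bonded chain carbon bound to a double-bonded chain carbon.

Among the compounds with values here, no measured step gives a size for this change. With no such guide, no shift beyond the scatter is expected in this assay and no direction is favoured, so the expected step is a step that the limit leaves unreadable from compound 2 to compound 4 on this estimate. Compound 4 is estimated at 15000 nM with 5000 nM to 40000 nM as the expected range, and a reading at the same limit is the likeliest outcome.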

Compound 4, half-maximal inhibitory concentration: 3500 nM
Beside the measured number, compound 4's estimate is 4.3-fold (0.63 log units) above it, outside the stated range (below it).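

In this assay, 4-(dimethylamino)phenyl in place of 2-fluoro-4-methoxyphenyl on a double-bonded chain carbon bound to a double-bonded chain carbon gives an at least 2.8-fold lower number from compound 2 to compound 4 (0.45 log units; beyond the scatter), so this position can carry a measurable change in antiproliferative activity. The two groups match in heavy atoms, hydrogen-bond donors and hydrogen-bond acceptors, and the swap puts a nitrogen in and takes an oxygen and a fluorine out. The size of this step is only a floor, and compound 4 is the one compound here with a number to compare against: the limit of > 10000 nM in this assay, at which 3 of the 4 values shown sit.

Going by these compounds alone, the single step cannot separate a gain from the dimethylamino group from the loss of the fluoro and methoxy substituents. Going by these compounds, how a primary amine or a morpholine would fare in place of the dimethylamino group remains open.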